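Bicyclic lactam caspase-8 inhibitors: ring-amine substituent change

The source may hold more compounds than are shown below. What is called first, only, known or untested is meant among the compounds shown, and "the series" means these compounds.

Measured so far:
compound 1, `CN1C[C@@H]2CCCC[C@H](NC(=O)c3ccccc3)C(=O)N2[C@H](C(=O)N[C@H]2CC(=O)OC2O)C1`: 247 nM
compound 2, `O=C1C[C@H](NC(=O)[C@@H]2COC[C@@H]3CCCC[C@H](NC(=O)c4cc5ccccc5s4)C(=O)N32)C(O)O1`: 429 nM

In an assay on isolated protein for inhibition of Caspase-8 (Homo sapiens) (on this read-out higher numbers stand for weaker inhibition and lower numbers for stronger inhibition), compound 1 gives 247 nM and stands at the lowest of the two numbers shown. Compound 2 gives 429 nM in this assay, a number within the scatter of compound 1, so the two cannot be placed in any order of potency. Among the compounds with values here, the two compounds differ at several places of the shared core and at the aromatic amide, and their agreement says only that such changes are tolerated.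

Compound 3, `O=C1C[C@H](NC(=O)[C@@H]2CN(C(=O)Nc3ccccc3)C[C@@H]3CCCC[C@H](NC(=O)c4ccccc4)C(=O)N32)C(O)O1`, is drawn from compound 1 by one change: phenylcarbamoyl in place of methyl on an amine nitrogen in a ring. Within the data shown here, no pair of measured compounds differs in a single place, so no measured step can serve as a guide for this change. With nothing to anchor a direction, the expectation for the step from compound 1 to compound 3 is a 1.0-fold higher number from compound 1 to compound 3 (0.01 log units; within the scatter), that is, no move beyond the scatter. Compound 3 is therefore estimated at 250 nM in this assay, with a range from 80 nM to 800 nM.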

Compound 3, half-maximal inhibitory concentration: 601 nM
Estimate against measurement, compound 3: 2.4-fold (0.38 log units) below; the range from low to high includes it.
By their numbers in this assay, from the lowest: compounds 1, 2 and 3 (each within the scatter of the next, the first and the last beyond it).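

The single-place step in the series gives the ring amine nitrogen a first direction: in this assay, phenylcarbamoyl in place of methyl gives a 2.4-fold higher number from compound 1 to compound 3 (0.39 log units; beyond the scatter), a modest rise. The earlier compounds shown here differed in several places and could not isolate this nitrogen, whereas this step ties the change in number to this substituent alone. The step also shows that this nitrogen can carry phenylcarbamoyl, with its six-membered aromatic ring, hydrogen-bond donor and hydrogen-bond acceptor, while compound 3 still gives a measurable value in this assay, so inhibition is weakened but not lost. No measurement here accounts for the rise.

One step cannot show whether the rise follows the phenyl ring, the carbonyl or the amide hydrogen of phenylcarbamoyl, and acetyl or benzyl on the same nitrogen would help to separate these parts. Also open, as far as these compounds go, is how an unsubstituted ring amine would compare with methyl at this position, and whether the step from methyl to phenylcarbamoyl would keep its size with a different aromatic amide on the shared core.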